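Benzoyl Amide in Place of the Azidonitrophenyl Arm

The source may hold more compounds than are shown below. What is called first, only, known or untested is meant among the compounds shown, and "the series" means these compounds.

Compound 1 `N#CN/C(=N\CCCNc1ccc(N=[N+]=[N-])cc1[N+](=O)[O-])NCCCCOc1cccc(CN2CCCCC2)c1` gives 6.56 in a functional assay on cardiac atrium for antagonist activity at histamine H2 receptor (Cavia porcellus); a higher number here means a more potent compound, by a factor of ten per unit of this negative logarithm, a lower number a less potent compound. This is the lower of the two numbers at hand: compound 2 `N#CN/C(=N\CCNC(=O)c1ccncc1)NCCCOc1cccc(CN2CCCCC2)c1` gives 6.89 in this assay, a gap beyond the usual scatter. Compound 3 `N#CN/C(=N\CCCNC(=O)c1ccccc1)NCCCCOc1cccc(CN2CCCCC2)c1` has not yet been measured in this assay. It differs from compound 1 by benzoyl in place of 4-azido-2-nitrophenyl on an amine nitrogen. Among the compounds with values here, no measured pair shows this exact change, so the expectation leans on compound 2, whose carbonyl-linked aromatic ring on the same kind of nitrogen gives 6.89. Compound 3 is therefore expected to give 6.9, within 6.4 to 7.4. The expected step is a number 0.34 log units higher from compound 1 to compound 3 (beyond the scatter), a modest gain.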

Compound 3, negative logarithm of the antagonist equilibrium constant: 6.6
Estimate against measurement, compound 3: 0.30 log units above; the measured number falls inside the stated range.
By their numbers in this assay, from the lowest: compounds 1, 3 and 2 (each within the scatter of the next, the first and the last beyond it).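

In this assay, benzoyl in place of 4-azido-2-nitrophenyl on this amine nitrogen gives a number 0.04 log units higher from compound 1 to compound 3 (within the scatter), so the two groups read alike at this position. The azido and nitro groups are therefore not required to hold this level of antagonism, and this nitrogen accepts both a directly attached aromatic ring and a carbonyl-linked one. Nothing at hand explains this likeness. Still open, going by these compounds, is whether a carboxylic acid or an amine on the benzoyl ring, or a longer chain leading to this nitrogen, would shift the number beyond the scatter.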